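Chloro for methyl on the sulfonamide aryl of compound 1

The source may hold more compounds than are shown below. What is called first, only, known or untested is meant among the compounds shown, and "the series" means these compounds.

Measured so far:
- compound 1, `Cc1ccc(S(=O)(=O)N[C@H]2CCN(CCCOc3ccc(C(=O)C4CC4)cc3)C2)cc1`: 380 nM
- compound 2, `CC(=O)c1ccc(OCCCN2CC[C@H](NC(=O)c3ccc(C#N)cc3)C2)cc1`: 6100 nM

In an assay on isolated protein for binding affinity to histamine H2 receptor (Homo sapiens) (a lower number here means a stronger inhibitor, a higher number a weaker inhibitor), compound 1 gives 380 nM, the lowest of the two numbers, while compound 2 gives 6100 nM, beyond the scatter. Compound 3, `O=C(c1ccc(OCCCN2CC[C@H](NS(=O)(=O)c3ccc(Cl)cc3)C2)cc1)C1CC1`, is not yet measured. It differs from compound 1 by chloro in place of methyl on an aromatic carbon. Among the measured compounds shown here, with no measured step of this kind to draw on, only a small step is expected in this assay, in either direction or none beyond the scatter, so the step from compound 1 to compound 3 is estimated at a 1.1-fold lower number from compound 1 to compound 3 (0.04 log units; within the scatter). Compound 3 is therefore expected near 350 nM, between 120 nM and 1100 nM.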

Compound 3, inhibition constant: 290 nM
The estimate for compound 3 lay 1.2-fold (0.08 log units) above the measured number, within the range that was stated.
By their numbers in this assay, from the lowest: compounds 3 and 1 (each within the scatter of the next); then compound 2.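

In this assay, among the compounds shown here, chloro in place of methyl on the aromatic carbon para to a large group gives a 1.3-fold lower number from compound 1 to compound 3 (0.12 log units; within the scatter) and is the first step read at this position. It shows that, on the core of compound 1, 4-methylphenyl and 4-chlorophenyl cannot be told apart in this read-out. No available evidence bears on why the two groups match here.

From the compounds shown here alone, whether a methoxy group, an amine or a carboxylic acid at this position would fit as well stays open. So does whether chloro for methyl would give a similar result on another core.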